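The source may report more compounds than this note shows. Statements on the series, on what has been measured and on what is new or still open speak of the compounds shown alone.

Compound 1 `Cc1c(Nc2ccc(C#N)cc2Cl)ncnc1OC1C2COCC1CN(C(=O)OC1(C)CC1)C2` was tested in a functional assay on HEK293 cells for agonist activity at Glucose-dependent insulinotropic receptor (Mus musculus), read by fluorescence and cAMP accumulation, with a stated time of 30 min (on this read-out lower numbers stand for an effect already at smaller amounts and higher numbers for an effect only at larger amounts of compound), where compound 1 gives 33 nM. For the measured compounds named here, this is the lowest of the two numbers measured so far; the nearest neighbour is compound 2 `CC1(OC(=O)N2CC3COCC(C2)C3Oc2cc(Nc3ccc(C#N)cc3Cl)ncn2)CC1`, for which compound 2 gives 254 nM in this assay. Going by the values given here, the single step connecting the two, a 7.7-fold higher number from compound 1 to compound 2 (0.89 log units; beyond the scatter), comes from hydrogen in place of methyl on an aromatic carbon.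

Compound 3 `Cc1c(Oc2ccc(C#N)cc2Cl)ncnc1OC1C2COCC1CN(C(=O)OC1(C)CC1)C2` has not yet been measured. It differs from compound 1 in one place: 2-chloro-4-cyanophenoxy in place of (2-chloro-4-cyanophenyl)amino on an aromatic carbon. Among the compounds with values here, no measured step bears on this change, because the step from compound 1 to compound 2 concerns only the methyl group and leaves the (2-chloro-4-cyanophenyl)amino group untouched. Within the data shown here, the expectation therefore rests on no directly comparable pair and must be wide. Compound 3 is expected to give a somewhat higher number than compound 1, an estimated step of a 3.0-fold higher number from compound 1 to compound 3 (0.48 log units; beyond the scatter). The estimate for compound 3 in this assay is 100 nM, with an expected range from 20 nM to 600 nM.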

Compound 3, half-maximal effective concentration: 128 nM
Compound 3: the middle estimate sits 1.3-fold (0.11 log units) below what was measured; measured number inside the range.
By their numbers in this assay, from the lowest: compound 1; then compounds 3 and 2 (each within the scatter of the next).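

Replacing the (2-chloro-4-cyanophenyl)amino group with 2-chloro-4-cyanophenoxy on the same aromatic carbon gives, in this assay, a 3.9-fold higher number from compound 1 to compound 3 (0.59 log units; beyond the scatter), which shows that this position responds to a change in the linking atom alone, with the chlorine, the nitrile and the carbon-only aromatic ring all retained. The two groups have the same number of heavy atoms and hydrogen-bond acceptors, but the entering group has 0 hydrogen-bond donors where the leaving group has 1, so the loss of the amino hydrogen and the exchange of nitrogen for oxygen arrive together and this single pair cannot separate them. No measurement presented here offers an explanation for the higher number.

The compounds shown leave open how a methylamino, sulfur or methylene link would behave at this position, and so whether the amino link of compound 1 is the best choice among such groups. They also leave open whether the same exchange would give a step of similar size without the methyl group, since the compound lacking that methyl, compound 2 , carries only the amino link.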